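Tosylamide series: chloro to hydrogen on the anilide ring

This account rests on a few compounds, and the source may have more. Where it says the series, first, only, none or still open, it means among the compounds named here.

Compound 1 `COc1cc(N(Cc2ccc(Cl)cc2)S(=O)(=O)c2ccc(C)cc2)cc(OC)c1OC` and compound 2 `COc1cc(N(Cc2ccccc2)S(=O)(=O)c2ccc(C)cc2)cc(OC)c1OC` share a core and differ in one place: hydrogen in place of chloro on an aromatic carbon. In a functional assay on PC-3 cells (Homo sapiens) for inhibition, read by MTT assay, with a stated time of 48 h (on this read-out lower numbers stand for stronger inhibition and higher numbers for weaker inhibition), compound 1 gives 14600 nM and compound 2 gives 7810 nM, so that a 1.9-fold lower number from compound 1 to compound 2 (0.27 log units; within the scatter). Compound 3 `Cc1ccc(S(=O)(=O)N(Cc2nc3ccccc3[nH]2)c2ccc(Cl)cc2)cc1` carries a different core; the difference between the two cores is not broken down here. In this assay compound 3 gives 42200 nM, the highest of the three numbers, and its gaps to compound 1 and compound 2 are beyond the scatter. Compound 4 `Cc1ccc(S(=O)(=O)N(Cc2nc3ccccc3[nH]2)c2ccccc2)cc1` is not yet measured; it differs from compound 3 by hydrogen in place of chloro on an aromatic carbon, the same change that separates compound 1 from compound 2. With a single earlier instance, which stayed within the scatter, the expectation for compound 4 is a step of about the same size, a 1.8-fold lower number from compound 3 to compound 4 (0.25 log units; within the scatter), because compound 3 gives 42200 nM and the earlier pair moved by a 1.9-fold lower number from compound 1 to compound 2 (0.27 log units; within the scatter). In this assay compound 4 is therefore estimated at 24000 nM, with a range from 10000 nM to 60000 nM.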

Compound 4, half-maximal inhibitory concentration: > 50000 nM
Compound 4: a limit, no number; the forecaster's own chance of this, stated with the estimate: 15%; at least 2.0-fold (0.31 log units) between middle value and limit.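

In this assay compound 4 gives > 50000 nM, which is a limit of the assay and not a number. As far as these compounds go, the replacement of chloro by hydrogen on the core of compound 3 therefore reads only as a floor, an at least 1.1-fold higher number from compound 3 to compound 4 (0.07 log units; that floor lies within the scatter), and the true size of this step stays unknown. The result neither shows that the change carries over from one core to the other nor shows that it fails to, and one pair on each core sets no rule for the series: the same change on two cores in this assay, a 1.9-fold lower number (0.27 log units; within the scatter) from compound 1 to compound 2 and an at least 1.1-fold higher number (0.07 log units; that floor lies within the scatter) from compound 3 to compound 4; the limit leaves it open whether they differ.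

The compounds shown leave open whether another group on the same aromatic carbon, such as fluoro, methoxy or an amine, would move the number on either core. Also open, from the compounds shown here alone, is how the change from chloro to hydrogen would read on a third core, and whether it would fall in line with either of these two steps.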